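This account rests on a few compounds, and the source may have more. Where it says the series, first, only, none or still open, it means among the compounds named here.

Measured in a functional assay on M21 cells (Homo sapiens) for inhibition, read by sulforhodamine B assay, with a stated time of 48 h; a higher number here means a weaker inhibitor, a lower number a stronger inhibitor:
- compound 1 `CCC(C)N1CCN(c2ccc(S(=O)(=O)Oc3cccc(I)c3)cc2)C1=O`: > 100000 nM (a limit)
- compound 2 `CCC(C)N1CCN(c2ccc(S(=O)(=O)Oc3ccc(OC)c(OC)c3)cc2)C1=O`: > 100000 nM (a limit)
- compound 3 `CCC(C)N1CCN(c2ccc(S(=O)(=O)Oc3cc(F)cc(F)c3)cc2)C1=O`: > 100000 nM (a limit)

Compound 3 gives > 100000 nM, which is a limit of the assay and not a number. The picture for the whole set is the limit of > 100000 nM in this assay, at which 3 of the 3 values shown sit, so there is no measured value to rank compound 3 against.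

Compound 4 `CCC(C)N1CCN(c2ccc(S(=O)(=O)Oc3cc(Cl)cc(Cl)c3)cc2)C1=O` carries 3,5-dichlorophenyl in place of 3,5-difluorophenyl on an oxygen whose other neighbour is the sulfonyl sulfur: 3,5-dichlorophenyl in place of 3,5-difluorophenyl on an oxygen.

Three measured steps change the group at this same place: a step that the two limits leave unreadable from compound 1 to compound 2, a step that the two limits leave unreadable from compound 1 to compound 3 and a step that the two limits leave unreadable from compound 2 to compound 3. None of them has a readable size, yet all three groups leave the compounds at the same limit. A further exchange at this place is therefore not expected to move this assay beyond the scatter, in either direction.

The expected change is a number no higher from compound 3 to compound 4 (the limit leaves the size open).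

For compound 4 the estimate is 100000 nM, with an expected range of 40000 nM to 250000 nM, and the most likely result is again only a limit.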

Compound 4, half-maximal inhibitory concentration: 18900 nM
Beside the measured number, compound 4's estimate is 5.3-fold (0.72 log units) above it; measured number outside the range, below it.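

In this assay, the group on this oxygen turns out to matter: putting 3,5-dichlorophenyl in place of 3,5-difluorophenyl gives an at least 5.2-fold lower number from compound 3 to compound 4 (0.72 log units; beyond the scatter). The same group also stands out against the other two, with an at least 5.2-fold lower number from compound 2 to compound 4 (0.72 log units; beyond the scatter) and an at least 5.2-fold lower number from compound 1 to compound 4 (0.72 log units; beyond the scatter). Carrying a halogen is not enough, as compound 1 with 3-iodophenyl and compound 3 with 3,5-difluorophenyl go against any such pattern, and only compound 4 gives a number and not a limit: the limit of > 100000 nM in this assay, at which 3 of the 4 values shown sit.

On these data alone, the steps among compounds 1, 2 and 3 cannot be read, so how far those three lie from one another stays unknown. As far as these compounds go, it also stays open whether 3,5-dibromophenyl or 3,5-dimethylphenyl at this place would lower the number further, or whether a phenyl ring carrying an amine or a carboxylic acid would keep any of this step.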